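Compound 3 to compound 4: dibutylamino in place of dipropylamino

The source may hold more compounds than are shown below. What is called first, only, known or untested is meant among the compounds shown, and "the series" means these compounds.

Values in a functional assay on LNCaP cells (Homo sapiens) for antiproliferative activity, read by WST assay, with a stated time of 3 days; on this read-out higher numbers stand for weaker inhibition and lower numbers for stronger inhibition:
- compound 1 `CCN(CC)CCCCCOc1c(-c2cc(OC)c(OC)c(OC)c2)oc2ccccc2c1=O`: 10000 nM
- compound 2 `CCCN(CCC)CCCCOc1c(-c2cc(OC)c(OC)c(OC)c2)oc2ccccc2c1=O`: 16800 nM
- compound 3 `CCCN(CCC)CCCCCOc1c(-c2cc(OC)c(OC)c(OC)c2)oc2ccccc2c1=O`: 7600 nM

Compound 3 stands at the low end of these numbers, with a 2.2-fold lower number from compound 2 to compound 3 (0.34 log units; beyond the scatter) and a 1.3-fold lower number from compound 1 to compound 3 (0.12 log units; within the scatter). Compound 4 `CCCCN(CCCC)CCCCCOc1c(-c2cc(OC)c(OC)c(OC)c2)oc2ccccc2c1=O` has not yet been measured. It carries dibutylamino in place of dipropylamino on a saturated chain carbon, five bonds along the chain from an oxygen on an aromatic ring.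

Within the data shown here, the nearest precedent is the change from diethylamino to dipropylamino at the same place, which gave a 1.3-fold lower number from compound 1 to compound 3 (0.12 log units; within the scatter). Among the measured compounds shown here, the only step beyond the scatter, a 2.2-fold lower number from compound 2 to compound 3 (0.34 log units; beyond the scatter), is modest and is a different change, (dipropylamino)methyl in place of dipropylamino. One precedent is thin support, but no step beyond the scatter is expected in this assay. The estimated step is a 1.2-fold lower number from compound 3 to compound 4 (0.07 log units; within the scatter). The expected value for compound 4 is 6500 nM, within an estimated range of 2800 nM to 15000 nM.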

Compound 4, half-maximal inhibitory concentration: 7800 nM
Estimate against measurement, compound 4: 1.2-fold (0.08 log units) below; the measured number falls inside the stated range.
By their numbers in this assay, from the lowest: compounds 3, 4, 1 and 2 (each within the scatter of the next, the first and the last beyond it).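

In this assay, at the saturated chain carbon five bonds along the chain from an oxygen on an aromatic ring, dibutylamino does not separate from dipropylamino (a 1.0-fold higher number from compound 3 to compound 4 (0.01 log units; within the scatter)) or from diethylamino (a 1.3-fold lower number from compound 1 to compound 4 (0.11 log units; within the scatter)), so all three dialkylamino groups now lie within the scatter of one another at this place. Among these compounds, the only step to compound 4 beyond the scatter is modest and is a different change, (dibutylamino)methyl in place of dipropylamino (a 2.2-fold lower number from compound 2 to compound 4 (0.33 log units; beyond the scatter)), so the gain seen earlier with the added methylene also appears with dibutylamino. Nothing measured explains why the number stays flat across these amines.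

Open, from the compounds shown here alone, is whether a cyclic amine such as piperidine or morpholine would separate from these dialkylamino groups at this place. Also open, going by these compounds, is what a longer chain carrying the amine would do.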